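From 2,6-dihydroxybenzyl to 2,4-dihydroxybenzyl

This account rests on a few compounds, and the source may have more. Where it says the series, first, only, none or still open, it means among the compounds named here.

Compound 1 `Cc1cc(-c2c(F)cc3c(=O)c(Cc4c(O)cccc4O)cn(C4CC4)c3c2F)cc(C)n1`: 250 nM
Compound 2 `Cc1cc(-c2c(F)cc3c(=O)c(Cc4cccc(O)c4O)cn(C4CC4)c3c2F)cc(C)n1`: 880 nM

Among the compounds with values here, in a functional assay on P388 cells (Mus musculus) for cytotoxicity (a lower number here means a stronger inhibitor, a higher number a weaker inhibitor), compound 1 gives 250 nM, the lower of the two numbers so far, and its gap to compound 2 lies beyond the scatter. Compound 3 `Cc1cc(-c2c(F)cc3c(=O)c(Cc4ccc(O)cc4O)cn(C4CC4)c3c2F)cc(C)n1` has not yet been measured. It keeps the core of compound 1 and differs in one group: 2,4-dihydroxyphenyl in place of 2,6-dihydroxyphenyl on a saturated chain carbon bound to an aromatic carbon. There, 2,4-dihydroxyphenyl stands in place of 2,6-dihydroxyphenyl on a saturated chain carbon bound to an aromatic carbon.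

Within the data shown here, one measured step bears on this change: a 3.5-fold higher number from compound 1 to compound 2 (0.55 log units; beyond the scatter), where 2,3-dihydroxyphenyl replaces the same group. Among the measured compounds shown here, this step is modest, and no measurement yet tests 2,4-dihydroxyphenyl itself. A step of similar size towards a higher number is therefore expected, although a result within the scatter remains possible in this assay. The estimated step is a 2.0-fold higher number from compound 1 to compound 3 (0.30 log units; within the scatter). Compound 3 is expected at 500 nM, within an estimated range of 170 nM to 1500 nM.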

Compound 3, half-maximal inhibitory concentration: 210 nM
Compound 3: the middle estimate sits 2.4-fold (0.38 log units) above what was measured; the range from low to high includes it.
By their numbers in this assay, from the lowest: compounds 3 and 1 (each within the scatter of the next); then compound 2.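

In this assay the change from 2,6-dihydroxyphenyl to 2,4-dihydroxyphenyl on a saturated chain carbon bound to an aromatic carbon gives a 1.2-fold lower number from compound 1 to compound 3 (0.08 log units; within the scatter) and so does not separate these two groups. The same group set against 2,3-dihydroxyphenyl gives a 4.2-fold lower number from compound 2 to compound 3 (0.62 log units; beyond the scatter) and thus, of the three dihydroxyphenyl groups shown, only the 2,3-dihydroxyphenyl group of compound 2 stands apart, as its earlier step from compound 1 had suggested but could not establish alone. Nothing available explains why the arrangement of the two hydroxyl groups matters at this position.

From the compounds shown here alone, whether a single hydroxyl group would serve as well, or whether a methoxy group or an amine could replace a hydroxyl group, remains open. So does the effect of a longer chain in place of the single carbon of the benzyl group.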